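A few compounds are considered here, and "the series" means these few. Any claim that something is new, unique, unknown or untested is made for them only; others in the source may bear on it.

Three compounds have been measured in a functional assay on CWR22R cells (Homo sapiens) for antiproliferative activity, read by propidium iodide staining, with a stated time of 96 h; a lower number here means a stronger inhibitor, a higher number a weaker inhibitor:

compound 1, `CC(O)(CSc1ccc(S(F)(F)(F)(F)F)cc1)C(=O)Nc1ccc(C#N)c(C(F)(F)F)c1`, 18100 nM
compound 2, `CC(O)(CSc1ccc(S(F)(F)(F)(F)F)cc1)C(=O)Nc1ccc([N+](=O)[O-])c(C(F)(F)F)c1`, 9200 nM
compound 3, `CC(O)(COc1ccc(S(F)(F)(F)(F)F)cc1)C(=O)Nc1ccc(C#N)cc1C(F)(F)F`, 14700 nM

Compound 1 and compound 2 share one core and differ in a single place: nitro in place of cyano on an aromatic carbon. This change gave a 2.0-fold lower number from compound 1 to compound 2 (0.29 log units; within the scatter), a step that stays within the scatter of repeated measurements.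

Compound 3 has a different core from compound 1; the difference between the two cores is not broken down here. In this assay compound 3 and compound 1 give numbers within the scatter of each other, and the same holds for compound 3 against compound 2.

Compound 4, `CC(O)(COc1ccc(S(F)(F)(F)(F)F)cc1)C(=O)Nc1ccc([N+](=O)[O-])cc1C(F)(F)F`, has not yet been measured. It relates to compound 3 as compound 2 relates to compound 1: nitro in place of cyano on an aromatic carbon. The surroundings are not identical, since in compound 1 the exchanged group is ortho to a trifluoromethyl group, whereas in compound 3 it is meta to a trifluoromethyl group; the change is therefore the same kind of change, not the same one.

The expectation for compound 4 rests on that one earlier step: because compound 1 to compound 2 gave a 2.0-fold lower number from compound 1 to compound 2 (0.29 log units; within the scatter), a step of similar size is expected for a 2.0-fold lower number from compound 3 to compound 4 (0.29 log units; within the scatter), with room for the different surroundings. In this assay compound 4 is estimated at 7500 nM, expected to fall between 3000 nM and 20000 nM.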

Compound 4, half-maximal inhibitory concentration: 17100 nM
For compound 4 the middle estimate is 2.3-fold (0.36 log units) below the measured one, and the stated range covers the measured number.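

In this assay, the exchange of cyano for nitro on the core of compound 3 gave a 1.2-fold higher number from compound 3 to compound 4 (0.07 log units; within the scatter), and set beside the same exchange on the core of compound 1, the two steps do not differ beyond the scatter: the same change on two cores in this assay, a 2.0-fold lower number (0.29 log units; within the scatter) from compound 1 to compound 2 and a 1.2-fold higher number (0.07 log units; within the scatter) from compound 3 to compound 4, 2.3-fold (0.36 log units) apart, within the scatter of two such steps On both cores, then, nitro and cyano could not be told apart in this assay, and in that limited sense the result carried from one core to the other. This does not show that the change has the same effect on every core in the series, nor does it fix a direction for the change, since the two printed steps point opposite ways while each stays within the scatter, and two pairs are too few to show how far the surroundings of the exchanged group matter.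

The compounds shown carry only cyano or nitro at this place, so it remains open whether an amine, a carboxylic acid or a chlorine atom there would give a step beyond the scatter. Also open is what the sulfur and oxygen links contribute on their own, as no pair shown differs in that link alone.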